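Phenol oxygen substitution in the bombesin receptor subtype-3 series

The compounds below may be only part of what the source reports. "The series", "measured", "known", "first", "only" and "open" are said of these compounds alone.

Compound 1 `c1ccc(-c2nnn[nH]2)c(-c2ccc(CCc3nc(CC4CCCC4)c[nH]3)cc2)c1` gives 15 nM in an assay on isolated protein for binding affinity to Bombesin receptor subtype-3 (Homo sapiens); a lower number here means a stronger inhibitor, a higher number a weaker inhibitor. Compound 2 `CCC(C)(C)Cc1c[nH]c(CCc2ccc(-c3ccccc3O)cc2)n1` gives 31 nM in this assay, the higher of the two numbers, and its gap to compound 1 lies beyond the usual scatter. Compound 3 `CCC(C)(C)Cc1c[nH]c(CCc2ccc(-c3ccccc3OCc3nc(N)n[nH]3)cc2)n1` carries (3-amino-1H-1,2,4-triazol-5-yl)methyl in place of hydrogen on an oxygen on an aromatic ring. For the measured compounds named here, no measured pair shows a change of this kind, so the size of the step is open. The expected step of a 1.3-fold higher number from compound 2 to compound 3 (0.11 log units; within the scatter) is estimated to stay near the scatter, leaning slightly toward a higher number. Compound 3 is therefore estimated at 40 nM, with a range from 10 nM to 160 nM.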

Compound 3, half-maximal inhibitory concentration: 27 nM
Estimate against measurement, compound 3: 1.5-fold (0.17 log units) above; the measured number falls inside the stated range.
By their numbers in this assay, from the lowest: compounds 1, 3 and 2 (each within the scatter of the next, the first and the last beyond it).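

Going from hydroxy to (3-amino-1H-1,2,4-triazol-5-yl)methoxy gives a 1.1-fold lower number from compound 2 to compound 3 (0.06 log units; within the scatter) in this assay, so the free hydroxy hydrogen is not required for a value in this range, and this oxygen carries the added 7 heavy atoms without a shift beyond the scatter. For the compounds shown here, this is the only single-place step so far. No supporting measurement bears on this result. As far as these compounds go, whether this holds for other groups on the oxygen stays open: a plain methyl or a carboxymethyl group there would test whether the aminotriazole ring contributes anything.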